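This account rests on a few compounds, and the source may have more. Where it says the series, first, only, none or still open, it means among the compounds named here.

Measured so far:
compound 1 `COc1ccc(C(=O)/C=C/c2cc(-c3cc(OC)c(OC)c(OC)c3)n[nH]2)cc1OC` — -84%
compound 2 `COc1ccc(C(=O)/C=C/c2cc(-c3cc(OC)c(OC)c(OC)c3)n[nH]2)cc1` — 19%

In a functional assay on MDA-MB-231 cells (Homo sapiens) for cytotoxicity, read by sulforhodamine B assay, with a stated time of 48 h, tested at 100 uM (a higher number here means a weaker effect of the compound at the concentration tested, a lower number a stronger effect), compound 1 gives -84%, the lowest of the two numbers. Compound 2 gives 19%. Among the measured compounds shown here, the single measured step, a number 103 percentage points higher from compound 1 to compound 2 (beyond the scatter), is hydrogen in place of methoxy on an aromatic carbon of the shared core, and it was large. Compound 3 `COc1cc(C(=O)/C=C/c2cc(-c3cc(OC)c(OC)c(OC)c3)n[nH]2)cc(OC)c1OC` differs from compound 1 as follows: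
methoxy in place of hydrogen on an aromatic carbon
For the measured compounds named here, only that one step bears on this change, and it runs the opposite way: removing a methoxy weakened the effect sharply, so adding one is not expected to weaken it. Compound 3 is expected to give about -75%, between -110% and 5%. The expected step is a number 9 percentage points higher from compound 1 to compound 3 (within the scatter), small.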

Compound 3, a percentage reported as activity, at one concentration (the size of the read-out at that concentration, not a potency): -96%
For compound 3 the middle estimate is 21 percentage points above the measured one; measured number inside the range.
By their numbers in this assay, from the lowest: compound 3; then compound 1; then compound 2.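

In this assay, methoxy in place of hydrogen on the aromatic carbon ortho to a methoxy group gives a number 12 percentage points lower from compound 1 to compound 3 (beyond the scatter) and so adds to the effect of the core of compound 1 beyond the scatter. This modest step is smaller than a number 103 percentage points higher from compound 1 to compound 2 (beyond the scatter) but shows that methoxy substitution on this ring can still strengthen the effect. No measurement on hand accounts for either step.

Open, on these data alone, is whether ethoxy, a longer chain, or an amine at this position would keep this effect. Also open, as far as these compounds go, is whether a hydroxyl group would.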